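The source may report more compounds than this note shows. Statements on the series, on what has been measured and on what is new or still open speak of the compounds shown alone.

In a functional assay on HL-60 cells (Homo sapiens) for cytotoxicity, read by MTT assay, with a stated time of 72 h (a lower number here means a stronger inhibitor, a higher number a weaker inhibitor), compound 1 (`CC(C)(C)c1nc2ccccc2n1C(=O)c1cccc2ccccc12`) gives 130 nM while compound 2 (`COc1ccc(C(=O)n2c(C(C)C)nc3ccccc32)cc1`) gives 630 nM and so holds the higher of the two numbers, a gap beyond the scatter. Compound 3 (`COc1ccc(C(=O)n2c(C3CCCC3)nc3ccccc32)cc1`) differs from compound 2 in one place, with cyclopentyl in place of isopropyl on an aromatic carbon. Going by the values given here, no measured pair shows this change on its own, so the expectation rests on little. The expected step (a 1.7-fold lower number from compound 2 to compound 3 (0.22 log units; within the scatter)) is small, towards a lower number in this assay, and may not leave the scatter. For compound 3 the estimated value is 380 nM (range 130 nM to 1000 nM).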

Compound 3, half-maximal inhibitory concentration: 76 nM
Beside the measured number, compound 3's estimate is 5.0-fold (0.70 log units) above it, outside the stated range (below it).
By their numbers in this assay, from the lowest: compounds 3 and 1 (each within the scatter of the next); then compound 2.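

On the aromatic carbon between two ring nitrogen atoms, cyclopentyl in place of isopropyl gives an 8.3-fold lower number from compound 2 to compound 3 (0.92 log units; beyond the scatter) in this assay. This is the first single change shown at this position, and it shows that the number in this assay depends on the group carried there, with a ring of carbon only accepted in place of the open isopropyl. Nothing measured here accounts for the step.

From the compounds shown here alone, whether a smaller or larger carbon ring, such as cyclopropyl or cyclohexyl, would do the same remains open. So does the effect of an amine at this position.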